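A few compounds are considered here, and "the series" means these few. Any claim that something is new, unique, unknown or untested is made for them only; others in the source may bear on it.

Measured so far in an ADME assay on Vero cells (Chlorocebus sabaeus) for cytotoxicity, read by MTT assay, with a stated time of 72 h; on this read-out higher numbers stand for lower toxicity in this test and lower numbers for higher toxicity in this test:
compound 1 `O=c1nc(N2CCN(NC3CCCCC3)CC2)sc2c([N+](=O)[O-])cc(C(F)(F)F)cc12` — > 64 ug/mL (a limit of the assay)
compound 2 `O=c1nc(N2CCN(NCC3CCCCC3)CC2)sc2c([N+](=O)[O-])cc(C(F)(F)F)cc12` — 29.3 ug/mL
compound 3 `O=c1nc(N2CCN(NCCC3CCCCC3)CC2)sc2c([N+](=O)[O-])cc(C(F)(F)F)cc12` — > 64 ug/mL (a limit of the assay)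

Compound 3 stands at the limit of > 64 ug/mL in this assay, at which 2 of the 3 values shown sit; no number is known for it. Compound 4 `O=c1nc(N2CCN(NCC3CCCC3)CC2)sc2c([N+](=O)[O-])cc(C(F)(F)F)cc12` differs from compound 3 by cyclopentyl in place of cyclohexylmethyl on a saturated chain carbon bound to an amine nitrogen. For the measured compounds named here, the steps that bear on it are an at least 2.1-fold lower number from compound 1 to compound 2 (0.33 log units; beyond the scatter) and an at least 2.1-fold higher number from compound 2 to compound 3 (0.33 log units; beyond the scatter), while a step that the two limits leave unreadable from compound 1 to compound 3. Going by the values given here, compound 2, the one compound with a number rather than a limit, sits nearest in structure to compound 4, so for compound 4 a number within reach of the assay is expected, with an at least 1.4-fold lower number from compound 3 to compound 4 (0.15 log units; that floor lies within the scatter) as the expected step. Compound 4 is therefore estimated at 45 ug/mL, within 22 ug/mL to 90 ug/mL.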

Compound 4, half-maximal cytotoxic concentration: > 64 ug/mL
Compound 4: a limit, no number; the forecaster's own chance of this, stated with the estimate: 45%; middle value at least 1.4-fold (0.15 log units) from the limit.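

In this assay compound 4 gives > 64 ug/mL, a limit of the assay and not a number. Cyclopentyl in place of cyclohexyl on a saturated chain carbon bound to an amine nitrogen gives an at least 2.1-fold higher number from compound 2 to compound 4 (0.33 log units; beyond the scatter), so at this place the ring, and not only the chain carrying it, moves the read-out. The steps from compound 3 to compound 4 and from compound 1 to compound 4 cannot be read, and compound 2 remains the only compound with a number: the limit of > 64 ug/mL in this assay, at which 3 of the 4 values shown sit.

Going by these compounds, whether a phenyl or cycloheptyl ring at this place gives a number rather than a limit stays open. On these data alone, the order of compound 1, compound 3 and compound 4 also stays open.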